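This account rests on a few compounds, and the source may have more. Where it says the series, first, only, none or still open, it means among the compounds named here.

Three compounds sharing one core have so far been taken to an ADME assay on L6 cells (Rattus norvegicus) for cytotoxicity, with a stated time of 72 h; on this read-out lower numbers stand for stronger inhibition and higher numbers for weaker inhibition. Compound 2 (`CCN(CC)CC(=O)OC1CC2(N(C)C)CC(c3ccccc3)C1C(c1ccccc1)C2`) gives 30100 nM, and compound 3 (`CCN(CC)CC(=O)OC1CC2(N3CCCCC3)CC(c3ccccc3)C1C(c1ccccc1)C2`) gives 23900 nM. For the measured compounds named here, these are the only two numbers available, and a 1.3-fold lower number from compound 2 to compound 3 (0.10 log units; within the scatter) means they cannot be told apart. Compound 1 (`CC(=O)OC1CC2(N(C)C)CC(c3ccccc3)C1C(c1ccccc1)C2`) has the entry "not determined" (no result reported), so it offers no number for comparison.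

Compound 4 (`CN(C)C12CC(OC(=O)C(C)(C)C)C(C(c3ccccc3)C1)C(c1ccccc1)C2`) has not yet been measured. Its difference from compound 2 is tert-butyl in place of (diethylamino)methyl on a carbonyl carbon. Put simply, tert-butyl stands in place of (diethylamino)methyl on a carbonyl carbon.

Going by the values given here, no measured step covers a change at this place, so the evidence is only indirect. Among the compounds with values here, the one measured step, a 1.3-fold lower number from compound 2 to compound 3 (0.10 log units; within the scatter), puts piperidin-1-yl in place of dimethylamino on a saturated ring carbon, which is a different place in the structure. Within the data shown here, it shows only that one change to this core left the number within the scatter. On that thin basis, no shift beyond the scatter can be predicted in either direction, and the range must stay wide. The expected change is a 1.2-fold higher number from compound 2 to compound 4 (0.07 log units; within the scatter). For compound 4 the estimated value is 35000 nM, with an expected range from 12000 nM to 100000 nM.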

Compound 4, half-maximal inhibitory concentration: 5060 nM
Compound 4: the middle estimate sits 6.9-fold (0.84 log units) above what was measured; measured number below the stated range.
By their numbers in this assay, from the lowest: compound 4; then compounds 3 and 2 (each within the scatter of the next).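

In this assay, the place on a carbonyl carbon responds clearly: putting tert-butyl in place of (diethylamino)methyl gives a 5.9-fold lower number from compound 2 to compound 4 (0.77 log units; beyond the scatter). For the compounds shown here, the earlier change, piperidin-1-yl in place of dimethylamino on a saturated ring carbon, gave only a 1.3-fold lower number from compound 2 to compound 3 (0.10 log units; within the scatter), so the earlier compounds left open whether any single change could move this number on the shared core beyond the scatter, and this step shows that one can. Nothing measured alongside these compounds accounts for the shift, so the step records a difference in the read-out and offers no explanation for it.

The leaving group holds a nitrogen and the entering group is all carbon and branched, and with both differences in one step, the compounds shown cannot tell which of them goes with the lower number. From the compounds shown here alone, an unbranched butyl chain or a cyclohexyl ring on the same carbonyl carbon would bear on that question, and it also remains open whether tert-butyl would give a similar step on the piperidin-1-yl compound.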